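The source may hold more compounds than are shown below. What is called first, only, known or untested is meant among the compounds shown, and "the series" means these compounds.

In an ADME assay on HEL cells (Homo sapiens) for cytotoxicity (on this read-out lower numbers stand for higher toxicity in this test and higher numbers for lower toxicity in this test), three compounds carrying the same core have been measured. Compound 1, `C/C(=N\NC(=O)COc1cccc2ccccc12)c1ccc(C#N)cc1Br`, gives 12.7 ug/mL. Compound 2, `Cc1ccc(/C=N/NC(=O)COc2cccc3ccccc23)cc1`, gives 80.1 ug/mL. Compound 3, `COc1cc(/C=N/NC(=O)COc2cccc3ccccc23)cc(OC)c1O`, gives 52.8 ug/mL.

Compound 2 stands at the highest number of the three, yet this needs a caveat: the value of compound 3 lies within the usual scatter of this assay, so the two cannot be told apart, and only compound 1 is clearly set off, at a markedly lower number, meaning it is the more toxic of that pair.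

Compound 4, `COc1ccc(/C=N/NC(=O)COc2cccc3ccccc23)cc1`, has not yet been measured. It differs from compound 2 in one place: methoxy in place of methyl on an aromatic carbon. This is a small change at the far end of the molecule, and compound 3, which carries methoxy groups on the same ring, gives a number within the scatter of compound 2. On this basis no step beyond the scatter is expected: the estimate for the step from compound 2 to compound 4 is a 1.1-fold lower number from compound 2 to compound 4 (0.06 log units; within the scatter). Compound 4 is therefore expected to give about 70 ug/mL, with a plausible range from 35 ug/mL to 140 ug/mL.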

Compound 4, half-maximal cytotoxic concentration: 100 ug/mL
Compound 4: middle estimate off by 1.4-fold (0.15 log units), on the low side, and the stated range covers the measured number.
By their numbers in this assay, from the lowest: compound 1; then compounds 3, 2 and 4 (each within the scatter of the next).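

In this assay, replacing methyl with methoxy on the aromatic carbon para to a large group gives a 1.2-fold higher number from compound 2 to compound 4 (0.10 log units; within the scatter) and so stays within the scatter, which means this read-out does not separate the 4-methylphenyl and 4-methoxyphenyl groups at this position. The earlier compounds shown here offered no pair differing in only one place, whereas this pair isolates a single exchange that adds one oxygen and one hydrogen-bond acceptor without a measurable shift in the number. No measured information is available to explain this outcome.

Going by these compounds, the comparison covers only methyl and methoxy at this one position, so it remains open whether an amine, a carboxylic acid or a longer chain such as butoxy there would also leave the number within the scatter. On these data alone, it also remains open whether the same exchange from methyl to methoxy would give a similarly small step elsewhere on the molecule or in a compound with a different arrangement of groups on this ring.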